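Replacing the propylcarbamoyl group of compound 2

This account rests on a few compounds, and the source may have more. Where it says the series, first, only, none or still open, it means among the compounds named here.

For the measured compounds named here, compound 2 `CCCNC(=O)OC[C@H]1OC(n2cnc3c(NC4CCOC4)ncnc32)[C@H](O)[C@@H]1O` gives 235 nM in an assay on DDT1 cells (Cricetulus griseus) for binding affinity to adenosine receptor A1 (Homo sapiens), read by radioligand binding (on this read-out lower numbers stand for stronger inhibition and higher numbers for weaker inhibition), the highest of the three numbers measured so far. Compound 3 `O=C(NC1CC1)OC[C@H]1OC(n2cnc3c(NC4CCOC4)ncnc32)[C@H](O)[C@@H]1O` gives 209 nM, and a 1.1-fold lower number from compound 2 to compound 3 (0.05 log units; within the scatter). Compound 1 `CC/N=C(\S)OC[C@H]1OC(n2cnc3c(NC4CCOC4)ncnc32)[C@H](O)[C@@H]1O` gives 33 nM; the steps of a 7.1-fold higher number from compound 1 to compound 2 (0.85 log units; beyond the scatter) and a 6.3-fold higher number from compound 1 to compound 3 (0.80 log units; beyond the scatter) show that the sulfur-bearing group of compound 1 goes with a clearly lower number than either carbamoyl group. Compound 4 `O[C@@H]1[C@@H](CO/C(S)=N/C2CCCC2)OC(n2cnc3c(NC4CCOC4)ncnc32)[C@@H]1O` carries a group of 8 heavy atoms (6 carbon, 1 nitrogen, 1 sulfur; one five-membered non-aromatic ring of carbon only) in place of a group of 6 heavy atoms (4 carbon, 1 nitrogen, 1 oxygen; no ring), on an oxygen on a saturated carbon. Because a 7.1-fold higher number from compound 1 to compound 2 (0.85 log units; beyond the scatter) ran the other way for a related sulfur-bearing group, a step down toward stronger binding is expected, roughly a 7.8-fold lower number from compound 2 to compound 4 (0.89 log units; beyond the scatter). Compound 4 is therefore estimated at 30 nM, expected to fall within 10 nM to 90 nM.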

Compound 4, inhibition constant: 72 nM
For compound 4 the middle estimate is 2.4-fold (0.38 log units) below the measured one; the range from low to high includes it.
By their numbers in this assay, from the lowest: compound 1; then compound 4; then compounds 3 and 2 (each within the scatter of the next).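

Compound 4 puts a ring on the double-bonded nitrogen of the sulfur-bearing group, and in this assay cyclopentyl reads higher than ethyl (a 2.2-fold higher number from compound 1 to compound 4 (0.34 log units; beyond the scatter)). Even so, this group with cyclopentyl keeps a lower number than either carbamoyl group (a 3.3-fold lower number from compound 2 to compound 4 (0.51 log units; beyond the scatter); a 2.9-fold lower number from compound 3 to compound 4 (0.46 log units; beyond the scatter)). Nothing available here explains why these numbers moved. Still open, going by these compounds, is how a propyl or butyl chain, or a phenyl ring, on that nitrogen would read, so the two ethyl and cyclopentyl points do not yet describe a trend with size.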